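A few compounds are considered here, and "the series" means these few. Any claim that something is new, unique, unknown or untested is made for them only; others in the source may bear on it.

Measured so far:
compound 1 `Nc1nc(NC2CCCC2)c2ncn(/C=C3/CC3(CO)CO)c2n1`: > 300000 nM
compound 2 `CCOc1nc(N)nc2c1ncn2/C=C1/CC1(CO)CO`: > 300000 nM

The two compounds share one core and differ in a single substituent on an aromatic carbon. In an ADME assay on HFF cells (Homo sapiens) for cytotoxicity, with a stated time of 8 days (on this read-out lower numbers stand for higher toxicity in this test and higher numbers for lower toxicity in this test), compound 1 gives > 300000 nM, which is a limit of the assay rather than a number. In this assay compound 2 likewise gives > 300000 nM, again a limit. The step that the two limits leave unreadable from compound 1 to compound 2, ethoxy in place of cyclopentylamino, therefore has no readable size. Where compound 2 stands is known only as a limit, and the limit of > 300000 nM in this assay, at which 2 of the 2 values shown sit, records that both measured values sit there.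

Compound 3 `CCCCOc1nc(N)nc2c1ncn2/C=C1/CC1(CO)CO` is not yet measured. It differs from compound 2 by ethyl in place of hydrogen on a saturated chain carbon, two bonds along the chain from an oxygen on an aromatic ring. For the measured compounds named here, no measured step tests a lengthening of this chain, and the only step available, a step that the two limits leave unreadable from compound 1 to compound 2, is itself unreadable, so no direction can be drawn from the data. Compound 3 is therefore expected to sit at the same limit, with an estimated value of 300000 nM (range 150000 nM to 600000 nM), which means an expected step of a number no higher from compound 2 to compound 3 (the limit leaves the size open), none beyond the scatter.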

Compound 3, half-maximal cytotoxic concentration: > 300000 nM
Compound 3: a limit, no number; the forecaster's own chance of this, stated with the estimate: 85%; the middle value sits exactly at the limit.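

In this assay compound 3 gives > 300000 nM, a limit and not a number. The steps among compound 1, compound 2 and compound 3 therefore cannot be read, and none has a size: the limit of > 300000 nM in this assay, at which 3 of the 3 values shown sit. The compounds shown leave open whether ethoxy to butoxy, or cyclopentylamino to either group, changes the half-maximal cytotoxic concentration at all.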